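Bromo for Methyl on a Fused Amine Scaffold

The compounds below may be only part of what the source reports. "The series", "measured", "known", "first", "only" and "open" are said of these compounds alone.

Compound 1 `Nc1cc(-c2ccc(Br)cc2)nc2cc(-c3ccc(Cl)cc3)nn12` gives 70.7% in a functional assay on the whole organism (strain Wistar) for inhibition, with Rattus norvegicus as the target, read by paw edema, with stated times of 30 min and 3 h, at a dose of 50 mg/kg by the oral route; a higher number here means more inhibition at the dose given (going by the name of the read-out), a lower number less inhibition.
Compound 2 `Cc1ccc(-c2cc(N)n3nc(-c4ccc(Cl)cc4)cc3n2)cc1` gives 69.5% in this assay.
Compound 3 `Cc1ccc(-c2cc3nc(-c4ccc(Cl)cc4)cc(N)n3n2)cc1` gives 64.6% in this assay.

Compound 2 and compound 1 differ in a single place:

bromo in place of methyl on an aromatic carbon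

That change gave a number 1.2 percentage points higher from compound 2 to compound 1 (within the scatter), so the two readings sit within the usual scatter of one another and show no real separation. Compound 3 is built from the same atoms as compound 2, joined differently; how the two cores differ is not broken down here. Compound 3 stands lowest of the three numbers, but each gap to the other two lies within the scatter.

Compound 4 `Nc1cc(-c2ccc(Cl)cc2)nc2cc(-c3ccc(Br)cc3)nn12` has not yet been measured. It differs from compound 3 by the same change seen between compound 2 and compound 1, at a place described in the same words:

bromo in place of methyl on an aromatic carbon

Among the compounds with values here, the step of a number 1.4 percentage points higher from compound 3 to compound 4 (within the scatter) is expected to be small, resting on a number 1.2 percentage points higher from compound 2 to compound 1 (within the scatter), the one measured example of this change. Compound 4 is therefore expected to give about 66% in this assay, with a plausible range from 56% to 76%.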

Compound 4, a percentage reported as inhibition, in the whole organism at one dose (the size of the read-out at that dose, not a potency): 56.1%
For compound 4 the middle estimate is 9.9 percentage points above the measured one; the measured number falls inside the stated range.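

In this assay putting 4-bromophenyl in place of 4-methylphenyl gave a number 8.5 percentage points lower from compound 3 to compound 4 (within the scatter) on the second core, so here too the change produces no separation beyond ordinary variation between repeated measurements. Set side by side, the two steps give no sign that the change behaves differently on the two cores: the same change on two cores in this assay, a number 1.2 percentage points higher (within the scatter) from compound 2 to compound 1 and a number 8.5 percentage points lower (within the scatter) from compound 3 to compound 4, 9.7 percentage points apart, within the scatter of two such steps.
Within the data shown here, this does not prove that the change has no effect or that it carries over exactly: there are only two examples, each read at a single dose in one whole-animal test, and a real but modest effect could be hidden within the scatter.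

The compounds shown have only methyl and bromo at this place, so it remains open whether another group there, such as methoxy, an amine or a carboxylic acid, would shift the reading beyond the scatter. A reading at one dose also leaves open how the compounds would compare across a range of doses.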